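The source may report more compounds than this note shows. Statements on the series, on what has been measured and on what is new or still open speak of the compounds shown alone.

Measured compounds:

Compound 1, `O=C(C#Cc1ccncc1)c1ccccc1`: 16000 nM
Compound 2, `O=C(/C=C/c1ccncc1)c1ccc(Cl)cc1`: 60000 nM
Compound 3, `COc1cc(C(=O)/C=C/c2cc[n+](C)cc2)cc(OC)c1OC`: > 50000 nM

In a functional assay with Rattus norvegicus as the target (a higher number here means a weaker inhibitor, a lower number a stronger inhibitor), compound 1 gives 16000 nM and compound 2 gives 60000 nM. Compound 3 does not give a number in this assay; its value of > 50000 nM is a limit of the assay, and the limit of > 50000 nM in this assay, at which 1 of the 3 values shown sits, describes that limit. Among the two actual numbers, compound 2 stands highest, with compound 1 the nearest and lower by a gap beyond the usual scatter.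

The step that follows runs from compound 2 to compound 4, `O=C(/C=C/c1ccncc1)c1ccccc1`, which has not yet been measured in this assay. The change is hydrogen in place of chloro on an aromatic carbon, para to a large group. Going by the values given here, no matched pair among the measured compounds shows what this change does here, so the expected size of the step rests only on compound 1 and compound 2. Because compound 1, which also carries an unsubstituted ring, gives 16000 nM, compound 4 is expected to sit somewhat lower than compound 2, with a step of a 2.4-fold lower number from compound 2 to compound 4 (0.38 log units; beyond the scatter) expected. Compound 4 is estimated at 25000 nM, within a range from 8000 nM to 80000 nM.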

Compound 4, half-maximal inhibitory concentration: 49000 nM
For compound 4 the middle estimate is 2.0-fold (0.29 log units) below the measured one; low and high end bracket the measured number.
By their numbers in this assay, from the lowest: compound 1; then compounds 4 and 2 (each within the scatter of the next).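

In this assay, going by these compounds alone, putting hydrogen in place of chloro on an aromatic carbon, para to a large group, gives a 1.2-fold lower number from compound 2 to compound 4 (0.09 log units; within the scatter), the first step in this set that can be read from two compounds differing in one place; at this position, the chloro group shows no effect that can be told from the scatter. With the same unsubstituted ring in both, compound 1 gives 16000 nM and compound 4 gives 49000 nM, so the ring alone does not bring their numbers together, and the one place where they differ is the triple or double bond in the chain next to the carbonyl. The step also sits close to the one limit in the set, which belongs to compound 3: the limit of > 50000 nM in this assay, at which 1 of the 4 values shown sits.

The compounds shown carry only chloro and hydrogen at this position, so they leave open whether an amine or a carboxylic acid there would shift the number beyond the scatter. They also leave open whether the same exchange of chloro for hydrogen would give a comparable step on the core of compound 1.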